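A few compounds are considered here, and "the series" means these few. Any claim that something is new, unique, unknown or untested is made for them only; others in the source may bear on it.

Measured so far:
compound 1 `Cc1cn(-c2nccc(N3C[C@@H](C)N(c4ccnc([C@@H](C)O)n4)[C@@H](C)C3)n2)c(C)n1`: 7 nM
compound 2 `Cc1nc(-c2ccccc2)nc(N2C[C@@H](C)N(c3ccnc([C@@H](C)O)n3)[C@@H](C)C2)n1`: 39 nM

In an assay on isolated protein with sorbitol dehydrogenase (Rattus norvegicus) as the target (a lower number here means a stronger inhibitor, a higher number a weaker inhibitor), compound 1 gives 7 nM and compound 2 gives 39 nM, the higher of the two numbers, a gap that lies beyond the usual scatter. Compound 3 `Cc1ncnc(N2C[C@@H](C)N(c3ccnc([C@@H](C)O)n3)[C@@H](C)C2)n1` has not been measured. It differs from compound 2 in one place: hydrogen in place of phenyl on an aromatic carbon. For the measured compounds named here, no measured pair shows this change, so its effect is uncertain. Taking the phenyl off compound 2 is expected to give a somewhat weaker inhibitor, a step of a 3.1-fold higher number from compound 2 to compound 3 (0.49 log units; beyond the scatter) in this assay. Compound 3 is therefore estimated at 120 nM, with a range from 35 nM to 450 nM.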

Compound 3, half-maximal inhibitory concentration: 5 nM
Compound 3: middle estimate off by 24-fold (1.38 log units), on the high side; measured number below the stated range.
By their numbers in this assay, from the lowest: compounds 3 and 1 (each within the scatter of the next); then compound 2.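

In this assay, replacing the phenyl with hydrogen on this aromatic carbon gives a 7.8-fold lower number from compound 2 to compound 3 (0.89 log units; beyond the scatter). The phenyl is therefore not needed for strong inhibition in this series, and removing this six-membered ring of carbon atoms improves the number rather than worsening it. Nothing available here explains this gain. Still open, on these data alone, is what a small group other than hydrogen, such as a methoxy group or an amine, would do on this carbon, and whether potency changes gradually or abruptly as the group grows towards phenyl.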